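This account rests on a few compounds, and the source may have more. Where it says the series, first, only, none or still open, it means among the compounds named here.

Measured so far in an ADME assay on Vero 76 cells (Chlorocebus sabaeus) for cytotoxicity, read by crystal violet staining, with a stated time of 96 h; a higher number here means that more compound is tolerated, a lower number that less compound is tolerated:
compound 1 `CCCC[C@H]1CC[C@H](c2ccc(NC(=S)Nc3cccc(C(F)(F)F)c3)cc2)CC1` gives 17000 nM
compound 2 `CCNC(=S)Nc1cccc(C(F)(F)F)c1` gives > 100000 nM (a limit)
compound 3 `O=C(NC(=S)Nc1cccc(C(F)(F)F)c1)[C@H]1C[C@@H]2CC[C@H]1C2` gives 20000 nM

Compound 2 gives > 100000 nM as a limit and not as a number. For the measured compounds named here, compound 1 at 17000 nM and compound 3 at 20000 nM are the only numerical readings, and these two lie within the scatter of each other.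

Compound 4 `FC(F)(F)c1cccc(NC(=S)NCc2ccco2)c1` differs from compound 2 in one place (furan-2-yl in place of methyl on a saturated chain carbon bound to an amide-type nitrogen) and the same difference, cut one bond further out, reads ethyl to (furan-2-yl)methyl. Going by the values given here, no measured pair shows this change, so the size of the step cannot be read from the series. With compound 3 at 20000 nM as one of the few numbers available, a modest fall in the tolerated concentration is expected. A second reading at the limit would be no surprise for compound 4. The expected change is estimated as an at least 1.8-fold lower number from compound 2 to compound 4 (0.25 log units; that floor lies within the scatter) in this assay for now. Compound 4 is estimated at 55000 nM with an expected range from 20000 nM to 100000 nM in this series.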

Compound 4, half-maximal cytotoxic concentration: 50000 nM
Beside the measured number, compound 4's estimate is 1.1-fold (0.04 log units) above it; low and high end bracket the measured number.
By their numbers in this assay, from the lowest: compounds 1 and 3 (each within the scatter of the next); then compound 4. At a limit, above all of these: compound 2.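

In this assay, for the compounds shown here, furan-2-yl in place of methyl on a saturated chain carbon bound to an amide-type nitrogen gives the first step that can be read (an at least 2.0-fold lower number from compound 2 to compound 4 (0.30 log units; that floor lies within the scatter)). Compound 4 gives 50000 nM, so this place carries a five-membered aromatic ring with a number inside the range of the assay. The step is only a floor because compound 2 stands at a limit and not at a number: the limit of > 100000 nM in this assay, at which 1 of the 4 values shown sits.

A single step at this place gives no trend with the size of the group. Going by these compounds, whether phenyl, an amine, a carboxylic acid or a longer chain on the same carbon would read like furan-2-yl or like methyl remains open.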